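The compounds below may be only part of what the source reports. "The series", "measured", "known", "first", "only" and "open" are said of these compounds alone.

Measured so far:
- Compound 1, `CC(C)(C)Cc1c(-c2ccoc2)sc(N)c1C(=O)c1ccc(Cl)cc1`: 1%
- Compound 2, `CC(C)(C)Cc1c(-c2ccncc2)sc(N)c1C(=O)c1ccc(Cl)cc1`: 6%
- Compound 3, `CC(C)(C)Cc1c(-c2cc(F)ccc2F)sc(N)c1C(=O)c1ccc(Cl)cc1`: 1%

These three share one core and differ only in the aryl group on the ring carbon next to the ring sulfur. In an assay on CHO cells for displacement of a labelled ligand from adenosine receptor A3 (Homo sapiens), read by scintillation counting, tested at 10 uM (a lower number here means less inhibition, a higher number more inhibition at the concentration tested (going by the name of the read-out)), compound 3 gives 1%, the same reading as compound 1 and, together with compound 1, the lowest of the three numbers; the step of a number 5 percentage points lower from compound 2 to compound 3 (within the scatter) is within the scatter, so the three numbers in this assay are all low and level with one another at the tested concentration.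

Compound 4, `CC(C)(C)Cc1c(-c2ccc(Cl)c(Cl)c2)sc(N)c1C(=O)c1ccc(Cl)cc1`, has not yet been measured. It differs from compound 3 in one place: 3,4-dichlorophenyl in place of 2,5-difluorophenyl on an aromatic carbon. Within the data shown here, the steps that bear on this position are no change at the digits printed from compound 1 to compound 3 (within the scatter) and a number 5 percentage points lower from compound 2 to compound 3 (within the scatter), both within the scatter, and the step of a number 5 percentage points higher from compound 1 to compound 2 (within the scatter) is within the scatter as well. Three different aryl groups at this position have all left the inhibition near zero, so no step beyond the scatter is expected for compound 4 in this assay, and the expected change is a number 3 percentage points higher from compound 3 to compound 4 (within the scatter). The estimate for compound 4 is 4%, with a range from -8% to 18%.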

Compound 4, a percentage reported as inhibition, at one concentration (the size of the read-out at that concentration, not a potency): 1%
Beside the measured number, compound 4's estimate is 3 percentage points above it; the range from low to high includes it.
By their numbers in this assay, from the lowest: compounds 1, 3, 4 and 2 (each within the scatter of the next).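

In this assay, the change of two fluorine atoms for two chlorine atoms, placed differently on the phenyl ring, gives no change at the digits printed from compound 3 to compound 4 (within the scatter) and so does not move the reading on the aromatic carbon next to the ring sulfur. The comparisons with the other aryl groups agree, with a number 5 percentage points lower from compound 2 to compound 4 (within the scatter) and no change at the digits printed from compound 1 to compound 4 (within the scatter) as the steps, which extends the flat picture to a chlorinated phenyl group and leaves all four aryl groups shown at this position level with one another. No measurement shown here accounts for this flat result.

Going by these compounds, all four compounds carry an aromatic ring at this position, so it remains open whether an aminomethyl group, a carboxylic acid or a longer alkyl chain there would give a reading outside the scatter of these values. On these data alone, the neopentyl group, the amino group and the (4-chlorophenyl)carbonyl group are the same throughout, so their contribution to the reading also remains unknown.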